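Swapping the Benzyl Group on a Shared Core

A few compounds are considered here, and "the series" means these few. Any claim that something is new, unique, unknown or untested is made for them only; others in the source may bear on it.

Compound 1, `O=c1c2cnn(-c3ccc(F)cc3)c2ncn1CC1(O)CCN(Cc2ccc(Br)cc2)CC1`: 6700 nM
Compound 2, `N#Cc1ccccc1CN1CCC(O)(Cn2cnc3c(cnn3-c3ccc(F)cc3)c2=O)CC1`: 8100 nM
Compound 3, `COC(=O)c1ccccc1CN1CCC(O)(Cn2cnc3c(cnn3-c3ccc(F)cc3)c2=O)CC1`: "not determined" (no result reported)

These three compounds share one core and differ only in the group carried on a saturated chain carbon bound to an amine nitrogen in a ring. In an assay on Sf21 cells for inhibition of ubiquitin carboxyl-terminal hydrolase 7 (Homo sapiens), read by spectrophotometry, with stated times of 30 min and 2 h (a higher number here means a weaker inhibitor, a lower number a stronger inhibitor), compound 1 gives 6700 nM, and compound 2 gives 8100 nM. Going by the values given here, compound 2 has the highest of the two numbers, but its only neighbour, compound 1, lies within the scatter: a 1.2-fold higher number from compound 1 to compound 2 (0.08 log units; within the scatter). For compound 3 the entry in this assay reads "not determined" (no result reported).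

Compound 4, `COC(=O)c1ccc(CN2CCC(O)(Cn3cnc4c(cnn4-c4ccc(F)cc4)c3=O)CC2)c(Br)c1`, is not yet measured. It is made from compound 2 by this change: 2-bromo-4-(methoxycarbonyl)phenyl in place of 2-cyanophenyl on a saturated chain carbon bound to an amine nitrogen in a ring.

Among the compounds with values here, only one measured step bears on this, the move from a 4-bromophenyl to a 2-cyanophenyl at the same place, and that step stayed within the scatter: a 1.2-fold higher number from compound 1 to compound 2 (0.08 log units; within the scatter). Within the data shown here, with so little movement seen when the group at this place is changed, no step beyond the scatter is expected in this assay, though the range is kept wide because only one comparison exists. The estimate for compound 4 is 7000 nM, between 2500 nM and 20000 nM, which means an expected step of a 1.2-fold lower number from compound 2 to compound 4 (0.06 log units; within the scatter).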

Compound 4, half-maximal inhibitory concentration: 900 nM
Compound 4: the middle estimate sits 7.8-fold (0.89 log units) above what was measured, outside the stated range (below it).
By their numbers in this assay, from the lowest: compound 4; then compounds 1 and 2 (each within the scatter of the next).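

The group at this place on the shared core can matter after all, which the pair of compound 1 and compound 2 did not show. In this assay, the change from 2-cyanophenyl to 2-bromo-4-(methoxycarbonyl)phenyl gives a 9.0-fold lower number from compound 2 to compound 4 (0.95 log units; beyond the scatter) and the change from 4-bromophenyl to the same group gives a 7.4-fold lower number from compound 1 to compound 4 (0.87 log units; beyond the scatter) and so both steps lie clearly outside the usual variation, making compound 4 the strongest inhibitor of the three with a number. Nothing measured here gives a reason for this gain.

The entering group brings a bromine and a methoxycarbonyl together on the ring, so these compounds cannot show how much each contributes, and compound 3, which has an ester but no bromine, offers no number to help separate them. From the compounds shown here alone, whether the gain would survive with a carboxylic acid or an amide in place of the methoxycarbonyl, or with a chlorine in place of the bromine, also remains open.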